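The source may report more compounds than this note shows. Statements on the series, on what has been measured and on what is new or still open speak of the compounds shown alone.

Compound 1, `COc1cc(-n2ncnc2-c2ccc(OC(C)C)cc2)cc(OC)c1OC`, is the starting point. In a functional assay on HL-60 cells (Homo sapiens) for antiproliferative activity, read by MTT assay, with a stated time of 72 h (on this read-out higher numbers stand for weaker inhibition and lower numbers for stronger inhibition), compound 1 gives 700 nM. Among the three results shown, this is the only one that is a number. Compound 2, `COc1cc(-c2ncnn2-c2ccc(F)cc2)cc(OC)c1OC`, gives only a limit of the assay in this assay, namely > 10000 nM. Compound 3, `CCOc1ccccc1-c1ncnn1-c1cc(OC)c(OC)c(OC)c1`, likewise gives only a limit, > 10000 nM. Two of the three results therefore sit at the limit of > 10000 nM in this assay, at which 2 of the 3 values shown sit, and only compound 1 has a measured value to build on.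

Compound 4, `COc1cc(-n2ncnc2-c2ccc(OC(F)(F)F)cc2)cc(OC)c1OC`, is not yet measured. It differs from compound 1 in one place: trifluoromethyl in place of isopropyl on an oxygen on an aromatic ring. The isopropyl leaves and a trifluoromethyl enters, on the oxygen on the aromatic ring. Among the compounds with values here, no pair of measured compounds that differ in a single place is available, so the size of this step can only be expected, not read from the data. The step of a 2.1-fold higher number from compound 1 to compound 4 (0.33 log units; beyond the scatter) is expected to be small, toward weaker inhibition, and perhaps not beyond the usual scatter. Compound 4 is expected to give about 1500 nM, within a range from 400 nM to 6000 nM.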

Compound 4, half-maximal inhibitory concentration: > 10000 nM
Compound 4: only a limit was reported (the forecaster's own chance of this, stated with the estimate: 15%); at least 6.6-fold (0.82 log units) between middle value and limit.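

In this assay, within the data shown here, trifluoromethyl in place of isopropyl on the oxygen gives an at least 14-fold higher number from compound 1 to compound 4 (1.15 log units; beyond the scatter), the first single change that can be read, and it shows that activity depends strongly on which group sits at this place. Compound 4 gives > 10000 nM, which is a limit of the assay and not a number. Among these compounds, compound 1 therefore remains the only compound here with a measured value, and the other results all read the same way: the limit of > 10000 nM in this assay, at which 3 of the 4 values shown sit.

From the compounds shown here alone, whether a methyl, an ethyl or a longer chain such as butyl on this oxygen would read closer to compound 1 or to compound 4 remains open. So does the result of an amine in place of the isopropoxy group.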